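A few compounds are considered here, and "the series" means these few. Any claim that something is new, unique, unknown or untested is made for them only; others in the source may bear on it.

The two compounds measured in a functional assay on CRL2813 cells (Homo sapiens) for cytotoxicity, read by sulforhodamine B assay, with a stated time of 5 days (on this read-out lower numbers stand for stronger inhibition and higher numbers for weaker inhibition), share one core and differ in the groups attached to it. Compound 1, `O=C(Nc1cccc(C(F)(F)F)c1)N[C@H]1CC[C@H](Oc2cccc(C(F)(F)F)c2)CC1`, gives 1300 nM in this assay. Compound 2, `O=C(Nc1ccc(Br)cc1)N[C@H]1CC[C@H](Oc2ccc(F)cc2)CC1`, is the starting point for the step considered here. For compound 2 this assay reports only a limit, > 20000 nM, and not a number. Going by these compounds, compound 2 therefore stands at the limit of > 20000 nM in this assay, at which 1 of the 2 values shown sits, and its true value is unknown. Compound 3, `COc1cccc(NC(=O)N[C@H]2CC[C@H](Oc3ccc(F)cc3)CC2)c1`, has not yet been measured. It differs from compound 2 in one place: 3-methoxyphenyl in place of 4-bromophenyl on an amide-type nitrogen. Among the compounds with values here, no measured pair in this small set differs in exactly this way, so the size of such a step cannot be read from the data, and nothing measured here tells what a methoxy group does in place of a bromine. Given that compound 2 already sits at the limit, the expected step from compound 2 to compound 3 is a step that the limit leaves unreadable from compound 2 to compound 3, which is no change beyond the usual scatter. Compound 3 is expected to give about 25000 nM in this assay, most likely between 8000 nM and 80000 nM.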

Compound 3, half-maximal inhibitory concentration: 14000 nM
Compound 3: middle estimate off by 1.8-fold (0.25 log units), on the high side; low and high end bracket the measured number.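

For compound 2, this assay reports only a limit, > 20000 nM, and not a number. With 3-methoxyphenyl in place of 4-bromophenyl on the amide-type nitrogen and the rest of the molecule unchanged, compound 3 gives 14000 nM, so this position now has a real number to work from, and the change shows up as an at least 1.4-fold lower number from compound 2 to compound 3 (0.15 log units; that floor lies within the scatter). That figure is only a floor, so the data neither prove that the swap improves the read-out nor fix how large the true step is, because one end of the comparison is not a number: the limit of > 20000 nM in this assay, at which 1 of the 3 values shown sits.

The names 3-methoxyphenyl and 4-bromophenyl differ both in the group on the ring and in the number that tells where it sits, and the compounds shown do not reveal which of the two differences matters here. They also leave open what a quite different group on this phenyl ring, such as an amine or a carboxylic acid, would do at this place.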